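Methoxy position on the anilide of the shared core

This account rests on a few compounds, and the source may have more. Where it says the series, first, only, none or still open, it means among the compounds named here.

Within the data shown here, compound 2 `COc1cccc(NC(=O)/C=C/c2coc3cc(OC)ccc3c2=O)c1` holds the only number in a functional assay on Huh-7 cells (Homo sapiens) for inhibition, read by MTT assay, with a stated time of 48 h; a lower number here means a stronger inhibitor, a higher number a weaker inhibitor: compound 2 gives 11100 nM. Compound 1 `COc1ccc2c(=O)c(/C=C/C(=O)Nc3cccc(Cl)c3)coc2c1` gives in this assay only a limit, > 100000 nM. The step of an at least 9.0-fold lower number from compound 1 to compound 2 (0.95 log units; beyond the scatter) is accordingly bounded by the limit of > 100000 nM in this assay, at which 1 of the 2 values shown sits. Compound 3 `COc1ccc2c(=O)c(/C=C/C(=O)Nc3ccccc3OC)coc2c1` differs from compound 2 by 2-methoxyphenyl in place of 3-methoxyphenyl on an amide-type nitrogen. Among the measured compounds shown here, no measured step moves a methoxy between ring positions; the one measured step swaps chloro for methoxy, so it bears only loosely here. The step to compound 3 is expected to stay within the scatter, a 1.4-fold higher number from compound 2 to compound 3 (0.13 log units; within the scatter). Compound 3 is estimated at 15000 nM, between 4000 nM and 60000 nM.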

Compound 3, half-maximal inhibitory concentration: 32300 nM
Compound 3: middle estimate off by 2.2-fold (0.33 log units), on the low side; low and high end bracket the measured number.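

In this assay, the methoxy placement on the anilide ring counts on its own: with the same atoms joined differently, 2-methoxyphenyl in place of 3-methoxyphenyl on the amide-type nitrogen gives a 2.9-fold higher number from compound 2 to compound 3 (0.46 log units; beyond the scatter). 2-Methoxyphenyl in place of 3-chlorophenyl gives an at least 3.0-fold lower number from compound 1 to compound 3 (0.49 log units; beyond the scatter). Compound 1 carries a limit of the assay, so this second step is only bounded: the limit of > 100000 nM in this assay, at which 1 of the 3 values shown sits.

Only these two methoxy placements can be compared here. From the compounds shown here alone, whether a longer alkoxy chain, an amine or a carboxylic acid on this ring would keep the number near that of compound 2 stays open.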